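The source may report more compounds than this note shows. Statements on the series, on what has been measured and on what is new or still open speak of the compounds shown alone.

For the measured compounds named here, two measured compounds share one core: a six-membered aromatic ring of carbon only that bears a carboxy group and a hydroxy group, with a small heterocycle attached. They are compound 1, `O=C(O)c1cc(-c2ncccn2)ccc1O`, and compound 2, `O=C(O)c1cc(-c2cscn2)ccc1O`. In a functional assay on the whole organism for inhibition, with Rattus norvegicus as the target, read by paw edema (a higher number here means that more compound is needed for the effect, a lower number that less compound is needed), compound 1 gives 100 mg/kg. In this assay compound 2 gives 95 mg/kg, and this number lies within the usual scatter of the number for compound 1, so the two compounds cannot be told apart on these data. Compound 3, `O=C(O)c1cc(-c2ncc[nH]2)ccc1O`, has not yet been measured. It differs from compound 2 in one place: 1H-imidazol-2-yl in place of 1,3-thiazol-4-yl on an aromatic carbon. Both groups are five-membered aromatic rings with two hetero atoms, and no step beyond the scatter is expected in this assay for this exchange. Compound 3 is therefore estimated to give 100 mg/kg, with a range from 50 mg/kg to 200 mg/kg. This estimate means a step of a 1.1-fold higher number from compound 2 to compound 3 (0.02 log units; within the scatter), expected to stay within the scatter.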

Compound 3, dose for half-maximal effect: 200 mg/kg
Beside the measured number, compound 3's estimate is 2.0-fold (0.30 log units) below it; the range from low to high includes it.
By their numbers in this assay, from the lowest: compounds 2, 1 and 3 (each within the scatter of the next, the first and the last beyond it).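

At the aromatic carbon meta to a carboxy group and para to a hydroxy group, the exchange of 1,3-thiazol-4-yl for 1H-imidazol-2-yl gives this assay a step beyond the scatter, a 2.1-fold higher number from compound 2 to compound 3 (0.32 log units; beyond the scatter), although a modest one. Both groups are five-membered aromatic rings with two hetero atoms, so that description alone does not settle the number at this position. The entering group has one hydrogen-bond donor and the leaving group none, and nitrogen takes the place of sulfur, but nothing available links the step to either difference.

As far as these compounds go, how an amine, a carboxylic acid or a longer chain at this position would compare remains open. So does whether a methyl group on the ring nitrogen of 1H-imidazol-2-yl would change the number.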